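Thiophen-2-yl to 4-methoxyphenyl swap: outlook for compound 4

A few compounds are considered here, and "the series" means these few. Any claim that something is new, unique, unknown or untested is made for them only; others in the source may bear on it.

Compound 1 `COc1cc(/C=C/C(=O)/C=C/c2cccs2)ccc1OCc1cn(CCCCCOc2cc(=O)oc3ccccc23)nn1` and compound 2 `COc1ccc(/C=C/C(=O)/C=C/c2ccc(OCc3cn(CCCCCOc4cc(=O)oc5ccccc45)nn3)c(OC)c2)cc1` are built on one core; compound 3 `COc1cc(/C=C/C(=O)/C=C/c2cccs2)ccc1OCc1cn(CCCCOc2cc(=O)oc3ccccc23)nn1` and compound 4 `COc1ccc(/C=C/C(=O)/C=C/c2ccc(OCc3cn(CCCCOc4cc(=O)oc5ccccc45)nn3)c(OC)c2)cc1` are built on another. The difference between the two cores is not broken down here.

In a functional assay on THP-1 cells (Homo sapiens) for inhibition, read by sulforhodamine B assay, with a stated time of 48 h, tested at 50 uM (on this read-out higher numbers stand for more inhibition of growth at the one concentration tested and lower numbers for less inhibition of growth), compound 1 gives 34%. Compound 2 gives 39% in this assay. The change from compound 1 to compound 2 is 4-methoxyphenyl in place of thiophen-2-yl on a double-bonded chain carbon bound to a double-bonded chain carbon and the step it made was a number 5 percentage points higher from compound 1 to compound 2 (within the scatter). Compound 3 gives 44% in this assay. The three values of compound 1, compound 2 and compound 3 all lie within the scatter of one another, so no order among them is drawn.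

Compound 4 carries the same change, applied to the core of compound 3: 4-methoxyphenyl in place of thiophen-2-yl on a double-bonded chain carbon bound to a double-bonded chain carbon. The place is described in the same words for both pairs, so it is the same change, seen once before in the series. Among the compounds with values here, only one earlier instance exists, so the expectation rests on that single step alone. For compound 4 the expected step is a number 5 percentage points higher from compound 3 to compound 4 (within the scatter), based on the earlier case in which the step of a number 5 percentage points higher from compound 1 to compound 2 (within the scatter) and stayed within the scatter. Compound 4 is therefore estimated at 49% in this assay, with a likely range from 36% to 61%.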

Compound 4, percent growth inhibition at one concentration: 45%
Compound 4: the middle estimate sits 4 percentage points above what was measured; measured number inside the range.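

In this assay, exchanging the thiophen-2-yl group for the 4-methoxyphenyl group gives a number 1 percentage points higher from compound 3 to compound 4 (within the scatter). Set beside the earlier case, the two steps do not differ: the same change on two cores in this assay, a number 5 percentage points higher (within the scatter) from compound 1 to compound 2 and a number 1 percentage points higher (within the scatter) from compound 3 to compound 4, 4 percentage points apart, within the scatter of two such steps

The change therefore carries from one core to the other without a step beyond the scatter on either, and the two cores give no sign of treating it differently; what this does not show is any real gain from the change on either core, since neither step can be told apart from repeat scatter, nor does a reading at one concentration on two pairs make a rule for other cores in the series.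

The compounds shown leave open whether a group of another kind in place of thiophen-2-yl, such as one carrying an amine or a carboxylic acid, would give a step beyond the scatter at this place. They also leave open whether the same quiet picture would hold on a core with a longer chain than those shown, or at concentrations other than the single one tested.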